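The compounds below may be only part of what the source reports. "The series", "measured", "known", "first", "only" and "open" are said of these compounds alone.

Measured so far:

Compound 1 `O=C1OCCN1CCOc1nn(-c2ccccc2F)c2ccc(F)cc12` — 2480 mL/min/kg
Compound 2 `CC(C)(O)CC(=O)N1CC[C@H]2CN(c3cccc4c3cnn4-c3ccccc3F)C(=O)[C@H]21` — 98.3 mL/min/kg
Compound 3 `CC(C)(C)OC(=O)N1CCN(c2cccc3c2cnn3-c2ccccc2F)C1=O` — 120 mL/min/kg

In an ADME assay on liver for metabolic stability, with Liver microsome (Rattus norvegicus) as the target, using microsomes and NADPH, with a stated time of 30 min, tested at 0.5 uM (a higher number here means faster removal of the compound, a lower number slower removal), compound 1 stands highest of the three numbers. Its gap to compound 3 is beyond the scatter, and its gap to compound 2 is larger still and also beyond the scatter; compound 2 and compound 3 themselves lie close together. Compound 1 is thus the compound removed fastest of those measured in this assay.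

Compound 4 `Fc1ccc2c(c1)c(OCCn1ccnc1)nn2-c1ccccc1F` has not been measured. It differs from compound 1 in one place: 1H-imidazol-1-yl in place of 2-oxo-1,3-oxazolidin-3-yl on a saturated chain carbon, two bonds along the chain from an oxygen on an aromatic ring

Among the measured compounds shown here, no step between measured compounds corresponds to this change, so the expectation rests on the number for compound 1 alone. Since compound 1 already gives 2480 mL/min/kg in this assay, compound 4 is expected to remain in the fast-removal region, and the step of a 1.7-fold lower number from compound 1 to compound 4 (0.22 log units; within the scatter) is expected to be small, downward if anything, and plausibly within the scatter. For compound 4 the estimate in this assay is 1500 mL/min/kg, with a range from 500 mL/min/kg to 4000 mL/min/kg.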

Compound 4, clearance: 1150 mL/min/kg
The estimate for compound 4 lay 1.3-fold (0.12 log units) above the measured number; low and high end bracket the measured number.
By their numbers in this assay, from the lowest: compounds 2 and 3 (each within the scatter of the next); then compound 4; then compound 1.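

In this assay, 1H-imidazol-1-yl in place of 2-oxo-1,3-oxazolidin-3-yl on a saturated chain carbon, two bonds along the chain from an oxygen on an aromatic ring, gives a 2.2-fold lower number from compound 1 to compound 4 (0.33 log units; beyond the scatter) as a modest first step at this position. The read-out therefore responds to the group at this chain end, though only modestly, and the high number of compound 1 does not depend on 2-oxo-1,3-oxazolidin-3-yl alone, since compound 4 still gives 1150 mL/min/kg in this assay with 1H-imidazol-1-yl in its place. Nothing measured here bears on what lies behind this step.

Still open, on these data alone, is whether an amine or a carboxylic acid at this chain end, or a longer chain to the same ring, would move the number further. Also open, as far as these compounds go, is whether this exchange gives a step of similar size on a different core.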